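A few compounds are considered here, and "the series" means these few. Any claim that something is new, unique, unknown or untested is made for them only; others in the source may bear on it.

Compound 1 `O=C(Nc1ccc(Oc2ccnc3[nH]ccc23)cc1)c1nn(-c2ccc(Cl)c(F)c2)ccc1=O` and compound 2 `O=C(Nc1ccc(Oc2ccnc3[nH]ccc23)cc1)c1nn(-c2ccc(Cl)c(C(F)(F)F)c2)ccc1=O` are built on one shared core, while compound 3 `Cn1ccc2c(Oc3ccc(NC(=O)c4nn(-c5ccc(Cl)c(F)c5)ccc4=O)cc3F)ccnc21` and the not yet measured compound 4 `Cn1ccc2c(Oc3ccc(NC(=O)c4nn(-c5ccc(Cl)c(C(F)(F)F)c5)ccc4=O)cc3F)ccnc21` are built on another; the difference between the two cores is not broken down here. In a functional assay on MCF7 cells (Homo sapiens) for cytotoxicity, read by MTT assay, with a stated time of 72 h (on this read-out higher numbers stand for weaker inhibition and lower numbers for stronger inhibition), compound 1 gives 3110 nM and compound 2 gives 6270 nM. The change that separates them is trifluoromethyl in place of fluoro on an aromatic carbon, and it produced a 2.0-fold higher number from compound 1 to compound 2 (0.30 log units; within the scatter). In this assay compound 3 gives 16600 nM, the highest number among the three measured compounds. Compound 4 carries the same change relative to compound 3, namely (trifluoromethyl in place of fluoro on an aromatic carbon), and the surroundings of the place are described in the same words for both pairs. Among the compounds with values here, the step from compound 3 to compound 4 is expected to be a 1.8-fold higher number from compound 3 to compound 4 (0.26 log units; within the scatter), because a 2.0-fold higher number from compound 1 to compound 2 (0.30 log units; within the scatter) is the only measured example of this change and lies within the scatter. Compound 4 is therefore estimated at 30000 nM in this assay, with a likely range from 12000 nM to 80000 nM.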

Compound 4, half-maximal inhibitory concentration: 18400 nM
Estimate against measurement, compound 4: 1.6-fold (0.21 log units) above, within the range that was stated.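

In this assay, trifluoromethyl in place of fluoro on the aromatic carbon gives a 1.1-fold higher number from compound 3 to compound 4 (0.04 log units; within the scatter), so on the core of compound 3 this step also stays within the scatter. Set beside the earlier step, the two cores give no sign of responding differently to the change: the same change on two cores in this assay, a 2.0-fold higher number (0.30 log units; within the scatter) from compound 1 to compound 2 and a 1.1-fold higher number (0.04 log units; within the scatter) from compound 3 to compound 4, 1.8-fold (0.26 log units) apart, within the scatter of two such steps. Within the data shown here, this does not show that the change has no effect in general or that it carries over to other cores: only two pairs are at hand, both read in a single cell assay, and steps this small could conceal a modest dependence on the core.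

The compounds shown leave open how a nitrile, a methoxy group or a plain hydrogen in that place would read on either core, and whether the step would stay the same without the chloro group. They also leave open what the difference between the two cores contributes on its own, as no pair shown isolates it in one place.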